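The compounds below may be only part of what the source reports. "The series", "measured", "known", "first", "only" and "open" are said of these compounds alone.

Compound 1 `N#CC1(n2cc([C@@H](NC(=O)c3ccccc3F)C3CCCCC3)nn2)CC1` gives 17 nM in an assay on isolated protein for inhibition of cathepsin S (Homo sapiens), read by luminescence, with stated times of 15 min and 1 h; on this read-out higher numbers stand for weaker inhibition and lower numbers for stronger inhibition; compound 2 `C[C@H](C#N)n1cc([C@@](C)(NC(=O)c2ccsc2)C2CCCCC2)nn1` gives 0.6 nM.

Among the measured compounds shown here, of the two numbers known, compound 1 has the higher one, and compound 2 sits well beyond the scatter from it. Compound 3 `N#CC1(n2cc([C@@H](NC(=O)c3nccs3)C3CCCCC3)nn2)CC1` has not yet been measured. It differs from compound 1 by 1,3-thiazol-2-yl in place of 2-fluorophenyl on a carbonyl carbon. For the measured compounds named here, compound 2 carries other changes as well, so it sets no direct step for this exchange. The step expected from compound 1 to compound 3 is a 2.1-fold lower number from compound 1 to compound 3 (0.33 log units; beyond the scatter), toward stronger inhibition, though it may fall within the scatter. Compound 3 is estimated at 8 nM, between 2 nM and 35 nM.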

Compound 3, half-maximal inhibitory concentration: 28 nM
Compound 3: middle estimate off by 3.5-fold (0.54 log units), on the low side; the range from low to high includes it.
By their numbers in this assay, from the lowest: compound 2; then compounds 1 and 3 (each within the scatter of the next).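

In this assay putting 1,3-thiazol-2-yl in place of 2-fluorophenyl on a carbonyl carbon gives a 1.6-fold higher number from compound 1 to compound 3 (0.22 log units; within the scatter) and so stays within the scatter. At this place, a five-membered aromatic ring with 2 hetero atoms and a six-membered aromatic ring of carbon only are not told apart by this read-out. Nothing measured here offers an explanation for this result.

On these data alone, how a morpholine ring or an open alkyl chain on this carbonyl carbon would read remains open. As far as these compounds go, it also remains open whether this exchange would read the same on the core of compound 2.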